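A few compounds are considered here, and "the series" means these few. Any claim that something is new, unique, unknown or untested is made for them only; others in the source may bear on it.

Working notes on the series. Compound 1 `CCCCC[C@H](C(C)C)C(c1ccc(O)c(OC)c1)c1ccc(O)c(OC)c1`, compound 2 `COc1cc(C(c2ccc(O)c(OC)c2)[C@H](C)[C@@H](C)CF)ccc1O` and compound 3 `COc1cc(C(c2ccc(O)c(OC)c2)[C@H](C)C(C)C)ccc1O` share one core and differ only along the saturated chain. In a functional assay on HL-60 cells (Homo sapiens) for cytotoxicity, read by WST assay, with a stated time of 48 h (a lower number here means a stronger inhibitor, a higher number a weaker inhibitor), compound 1 gives 9600 nM. In this assay compound 2 gives 45000 nM, and compound 3 gives 17000 nM. On these three numbers compound 3 stands second highest: its nearest neighbour is compound 1, with a 1.8-fold higher number from compound 1 to compound 3 (0.25 log units; within the scatter), and its furthest is compound 2, with a 2.6-fold lower number from compound 2 to compound 3 (0.42 log units; beyond the scatter).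

Compound 4 `COc1cc(C(c2ccc(O)c(OC)c2)[C@H](C)[C@@H](C)CO)ccc1O` is the next step out from compound 3: hydroxy in place of hydrogen on a saturated chain carbon, four bonds along the chain from two aromatic carbons. The step that bears on it is a 2.6-fold lower number from compound 2 to compound 3 (0.42 log units; beyond the scatter), where a one-heavy-atom group at this same place was taken away and the number fell modestly; read in the other direction, putting a one-heavy-atom group onto this carbon raised the number by that modest margin. The step of a 1.8-fold higher number from compound 1 to compound 3 (0.25 log units; within the scatter), a change at a different place on the chain, stayed within the scatter, so the chain end is where the numbers have moved. A modest rise beyond the scatter is therefore expected for compound 4, a 1.9-fold higher number from compound 3 to compound 4 (0.27 log units; within the scatter). Compound 4 is estimated at 32000 nM, in a range from 13000 nM to 80000 nM.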

Compound 4, half-maximal inhibitory concentration: > 100000 nM
Compound 4: no number, only a limit; the forecaster's own chance of this, stated with the estimate: 10%; middle value at least 3.1-fold (0.49 log units) from the limit.
By their numbers in this assay, from the lowest: compounds 1 and 3 (each within the scatter of the next); then compound 2. At a limit, above all of these: compound 4.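

For the compounds shown here, compound 4 stands at a limit of the assay and not at a number, and it is the only compound that does: the limit of > 100000 nM in this assay, at which 1 of the 4 values shown sits. On the saturated chain carbon four bonds along the chain from two aromatic carbons, hydroxy in place of hydrogen gives an at least 5.8-fold higher number from compound 3 to compound 4 (0.76 log units; beyond the scatter), and hydroxy in place of fluoro gives an at least 2.2-fold higher number from compound 2 to compound 4 (0.34 log units; beyond the scatter), so the two one-heavy-atom groups do not read alike and the identity of the group here counts, not only its presence. Measured against the compound with the longest chain, the change gives an at least 10-fold higher number from compound 1 to compound 4 (1.01 log units; beyond the scatter), the largest step in the series, whereas the change at a different place on the chain stayed within the scatter (a 1.8-fold higher number from compound 1 to compound 3 (0.25 log units; within the scatter)).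

As far as these compounds go, how far past its limit compound 4 lies stays open, so each of these steps gives only a minimum size. Also open, from the compounds shown here alone, is how a methoxy, an amine or a carboxylic acid would read on this same carbon, and whether hydroxy would raise the number as far on a chain that also carries the butyl group of compound 1.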